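Bromo-isatin aminomethyl series: piperidinyl for dimethylamino

The source may hold more compounds than are shown below. What is called first, only, known or untested is meant among the compounds shown, and "the series" means these compounds.

Measured so far in a functional assay on MDA-MB-468 cells (Homo sapiens) for cytotoxicity, read by sulforhodamine B assay, with a stated time of 48 h; a lower number here means a stronger inhibitor of growth, a higher number a weaker inhibitor of growth:
- compound 1 `Cc1ccc2nc(/N=C3\C(=O)N(CN(C)C)c4cccc(Br)c43)sc2c1` gives 27400 nM
- compound 2 `CN(C)CN1C(=O)C(=O)c2c(Br)cccc21` gives 49000 nM
- compound 3 `O=C1C(=O)N(CN2CCCCC2)c2cccc(Br)c21` gives 35300 nM

Compound 2 and compound 3 share one core and differ in a single place: piperidin-1-yl in place of dimethylamino on a saturated chain carbon bound to an amide-type nitrogen in a ring. Between them the read-out moves by a 1.4-fold lower number from compound 2 to compound 3 (0.14 log units; within the scatter), so the pair gives no sign that this change matters in this assay. Compound 1 carries a different core from compound 2; how the two cores differ is not broken down here. The values of compound 1 and compound 3 fall within the scatter of each other, as do those of compound 1 and compound 2, so no ordering among the three measured compounds is claimed.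

The unmeasured compound 4 `Cc1ccc2nc(/N=C3\C(=O)N(CN4CCCCC4)c4cccc(Br)c43)sc2c1` stands to compound 1 as compound 3 stands to compound 2: the change is piperidin-1-yl in place of dimethylamino on a saturated chain carbon bound to an amide-type nitrogen in a ring, on the core of compound 1. Because a 1.4-fold lower number from compound 2 to compound 3 (0.14 log units; within the scatter) lies within the scatter, the expected step is a 1.3-fold lower number from compound 1 to compound 4 (0.12 log units; within the scatter), a near-neutral move. Compound 4 is therefore estimated at 21000 nM, with the expected range from 9000 nM to 50000 nM.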

Compound 4, concentration for 50% growth inhibition: 24000 nM
Estimate against measurement, compound 4: 1.1-fold (0.06 log units) below, and the stated range covers the measured number.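

In this assay the swap of dimethylamino for piperidin-1-yl on the core of compound 1 gives a 1.1-fold lower number from compound 1 to compound 4 (0.06 log units; within the scatter) and so does not move the read-out beyond the scatter. The two cores give steps that cannot be told apart: the same change on two cores in this assay, a 1.4-fold lower number (0.14 log units; within the scatter) from compound 2 to compound 3 and a 1.1-fold lower number (0.06 log units; within the scatter) from compound 1 to compound 4, 1.2-fold (0.08 log units) apart, within the scatter of two such steps. For the compounds shown here, the near-neutral result of this change therefore carries from the core of compound 2 to the core of compound 1 in this assay, but it rests on only two pairs, neither step shows a measurable effect, and nothing follows for other cores or other assays.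

Still open, as far as these compounds go, is whether a different amine on the same saturated chain carbon, such as morpholine or piperazine, would give a step beyond the scatter. Also open, from the compounds shown here alone, is whether a longer chain carrying the piperidin-1-yl would do so on either core.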